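Benzimidazole substituent swap: hydroxymethyl to chloro

A few compounds are considered here, and "the series" means these few. Any claim that something is new, unique, unknown or untested is made for them only; others in the source may bear on it.

Measured compounds:
compound 1 `C[C@@H]1CN(c2sc(C(F)(F)F)nc2-c2nc3cc(OCCO)ccc3[nH]2)CCN1C(=O)Cn1cnc2cccnc21`, 99.1 nM
compound 2 `Cc1nc(C)n(CC(=O)N2CCN(c3sc(C(F)(F)F)nc3-c3nc4ccc(OC5CNC5)cc4[nH]3)C[C@H]2C)n1`, 580 nM
compound 3 `C[C@@H]1CN(c2sc(C(F)(F)F)nc2-c2nc3ccc(CO)cc3[nH]2)CCN1C(=O)Cn1cnc2cccnc21`, 92.4 nM

In a functional assay on Venous blood for antagonist activity at C-X-C chemokine receptor type 3 (Homo sapiens), read by flow cytometry, with a stated time of 30 min, in the presence of a further agent that is not named here (on this read-out lower numbers stand for stronger inhibition and higher numbers for weaker inhibition), compound 3 shows the lowest of the three numbers. Compound 1 gives 99.1 nM, a gap that lies within the scatter, so the two cannot be told apart. Compound 2 gives 580 nM, a gap beyond the scatter; compound 2 also carries a different acetamide group and a different group on the benzimidazole, so no single change accounts for it.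

Compound 4 `C[C@@H]1CN(c2sc(C(F)(F)F)nc2-c2nc3cc(Cl)ccc3[nH]2)CCN1C(=O)Cn1cnc2cccnc21` is not yet measured. It differs from compound 3 on an aromatic carbon of a five-membered aromatic ring with 1 nitrogen and 1 sulfur:
5-chloro-1H-benzimidazol-2-yl in place of 6-(hydroxymethyl)-1H-benzimidazol-2-yl on an aromatic carbon
Among the measured compounds shown here, no measured pair isolates this change. Compounds 1 and 3, which carry different groups on the benzimidazole yet sit within the scatter of each other, suggest that this ring tolerates variation, so the step in this assay is expected to be small and in no fixed direction. For compound 4 the expected step is a 1.0-fold higher number from compound 3 to compound 4 (0.01 log units; within the scatter), a value estimated at 95 nM with a range from 35 nM to 260 nM.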

Compound 4, half-maximal inhibitory concentration: 38.5 nM
Compound 4: middle estimate off by 2.5-fold (0.39 log units), on the high side; the measured number falls inside the stated range.
By their numbers in this assay, from the lowest: compound 4; then compounds 3 and 1 (each within the scatter of the next); then compound 2.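

In this assay, among the compounds shown here, the chloro group gives the first steps that can be read at this benzimidazole substituent: a 2.4-fold lower number from compound 3 to compound 4 (0.38 log units; beyond the scatter), and a 2.6-fold lower number from compound 1 to compound 4 (0.41 log units; beyond the scatter). Both steps are modest but beyond the scatter, so this substituent does affect the read-out, and chloro gives a lower number than either 6-(hydroxymethyl) or 2-hydroxyethoxy. No measured evidence bears on the origin of these steps.

The compounds shown cannot separate a contribution from chloro itself from the loss of the hydroxyl-bearing chains, and a methyl, methoxy or nitrile group, or an unsubstituted benzimidazole, would test this. As far as these compounds go, it also remains open whether chloro gives a similar step when paired with the acetamide group of compound 2.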